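The source may report more compounds than this note shows. Statements on the series, on what has been measured and on what is new or still open speak of the compounds shown alone.

Compound 1 `OCCOc1c(Br)cc(Br)cc1Oc1ccc(Br)cc1Br`: 34.5 ug/mL in a functional assay on U-937 cells (Homo sapiens) for cytotoxicity, read by MTT assay, with a stated time of 24 h; on this read-out higher numbers stand for weaker inhibition and lower numbers for stronger inhibition.
Compound 2 `BrCCCCCCOc1c(Br)cc(Br)cc1Oc1ccc(Br)cc1Br`: 33.8 ug/mL in this assay.
Compound 3 `Brc1ccc(Oc2cc(Br)cc(Br)c2OCCCCCN2CCN(c3ccccc3)CC2)c(Br)c1`: 42.5 ug/mL in this assay.

Compound 2 stands among three numbers that do not separate from one another: its step back to compound 1 and its gap to compound 3 are both within the usual scatter, so no ordering among these three can be read from the data. Compound 4 `OCCCOc1c(Br)cc(Br)cc1Oc1ccc(Br)cc1Br` has not yet been measured. It differs from compound 2 by hydroxy in place of 3-bromopropyl on a saturated chain carbon, three bonds along the chain from an oxygen on an aromatic ring. Within the data shown here, the one measured step that bears on this exchange is a 1.0-fold lower number from compound 1 to compound 2 (0.01 log units; within the scatter), in which a hydroxy at the position two bonds along the chain from an oxygen on an aromatic ring was replaced by 4-bromobutyl with no movement beyond the scatter. Compound 4 carries the reverse kind of exchange one bond further out, and nothing measured suggests a different outcome. The expected step is therefore a 1.0-fold higher number from compound 2 to compound 4 (0.00 log units; within the scatter), within the scatter. In this assay compound 4 is estimated at 34 ug/mL, with a range from 20 ug/mL to 58 ug/mL.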

Compound 4, half-maximal inhibitory concentration: 32.3 ug/mL
Compound 4: the middle estimate sits 1.1-fold (0.02 log units) above what was measured; the range from low to high includes it.
By their numbers in this assay, from the lowest: compounds 4, 2, 1 and 3 (each within the scatter of the next).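

In this assay, hydroxy in place of 3-bromopropyl, on a saturated chain carbon three bonds along the chain from an oxygen on an aromatic ring, gives a 1.0-fold lower number from compound 2 to compound 4 (0.02 log units; within the scatter) and so leaves the number within the scatter. This extends the earlier finding to a second chain length, and a direct comparison of two hydroxy-ended chains adds a 1.1-fold lower number from compound 1 to compound 4 (0.03 log units; within the scatter) for hydroxymethyl in place of hydroxy, so the added chain carbon also produces no separation. Nothing measured here speaks to why these values stay together.

As far as these compounds go, whether any end group at this place can move the number beyond the scatter remains open, as a carboxylic acid or a primary amine on the same chain would test. From the compounds shown here alone, a hydroxy-ended chain much longer than those in compound 1 and compound 4 is equally open.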